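A few compounds are considered here, and "the series" means these few. Any claim that something is new, unique, unknown or untested is made for them only; others in the source may bear on it.

Measured compounds: compound 1 `ClCc1cccc(Cn2cnc3nc(Cl)nc(Cl)c32)c1`, 55000 nM; compound 2 `ClCc1ccc(Cn2cnc3c(Cl)nc(Cl)nc32)cc1`, 60300 nM; compound 3 `ClCc1ccccc1Cn1cnc2c(Cl)ncnc21`, 55000 nM.

In a functional assay on IGROV-1 cells (Homo sapiens) for cytotoxicity, read by sulforhodamine B assay, with a stated time of 48 h (a lower number here means that less compound is tolerated, a higher number that more compound is tolerated), compound 1 stands level with compound 3 at the digits shown, the two together giving the lowest of the three numbers; compound 2 gives a number that is higher by an amount within the scatter, so nothing separates the three. Compound 4 `ClCc1cccc(Cn2cnc3ncnc(Cl)c32)c1` has not yet been measured in this assay. It differs from compound 1 in one place: hydrogen in place of chloro on an aromatic carbon. For the measured compounds named here, no pair of measured compounds differing in exactly one place is available, so the size of this step cannot be read from the data. Compound 3, which also carries a single chloro on the core, gives 55000 nM, a number level with compound 1, so no change beyond the scatter is expected. Compound 4 is therefore estimated at 55000 nM (range 30000 nM to 100000 nM), which would mean an expected step of no change at the digits printed from compound 1 to compound 4 (within the scatter).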

Compound 4, concentration lethal to 50% of the cells: 5880 nM
Compound 4: the middle estimate sits 9.4-fold (0.97 log units) above what was measured; the whole stated range lies above it.
By their numbers in this assay, from the lowest: compound 4; then compounds 1, 3 and 2 (each within the scatter of the next).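

In this assay, for the compounds shown here, hydrogen in place of the chloro between two ring nitrogen atoms gives a 9.4-fold lower number from compound 1 to compound 4 (0.97 log units; beyond the scatter) and so the first step that can be read at all. It shows that the number responds to what sits on this aromatic carbon of the core. Nothing shown here accounts for the size of this step. On these data alone, whether an amine or a methoxy group on the same carbon would leave the number nearer that of compound 1 or that of compound 4 stays open. So does whether hydrogen in place of the other chloro of compound 1 would give a similar step.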